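The source may hold more compounds than are shown below. What is called first, only, known or untested is meant among the compounds shown, and "the series" means these compounds.

In a functional assay on CHO-K1 cells for antagonist activity at transient receptor potential cation channel subfamily V member 1 (Homo sapiens), read by FLIPR (on this read-out higher numbers stand for weaker inhibition and lower numbers for stronger inhibition), compound 3 `Cc1ccc(Cl)cc1Nc1nc(C(F)(F)F)ccc1CNC(=O)C(C)c1ccc(NS(C)(=O)=O)c(F)c1` gives 140 nM, the lowest of the three numbers in hand. Compound 1 `CCCCNc1nc(C(F)(F)F)ccc1CNC(=O)C(C)c1ccc(NS(C)(=O)=O)c(F)c1` gives 293 nM, and compound 2 `CC(C(=O)NCc1ccc(C(F)(F)F)nc1NCC1CCN(C(=O)OC(C)(C)C)CC1)c1ccc(NS(C)(=O)=O)c(F)c1` gives 1140 nM. Among the compounds with values here, the one measured step between neighbours, a 2.1-fold lower number from compound 1 to compound 3 (0.32 log units; beyond the scatter), came with 5-chloro-2-methylphenyl in place of butyl on a nitrogen on an aromatic ring. Compound 4 `CCCN(CCC)c1nc(C(F)(F)F)ccc1CNC(=O)C(C)c1ccc(NS(C)(=O)=O)c(F)c1` differs from compound 3 by dipropylamino in place of (5-chloro-2-methylphenyl)amino on an aromatic carbon. Within the data shown here, no measured pair covers removal of the hydrogen-bond donor at this nitrogen; the only related comparison, compound 1 against compound 3, shows the alkyl amine giving the higher number. Compound 1 with 293 nM is taken as the nearest anchor. For compound 4 a step of a 3.6-fold higher number from compound 3 to compound 4 (0.55 log units; beyond the scatter) toward weaker inhibition is therefore expected. Compound 4 is estimated at 500 nM, in the range 150 nM to 1800 nM.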

Compound 4, half-maximal inhibitory concentration: 14.7 nM
Estimate against measurement, compound 4: 34-fold (1.53 log units) above; measured number below the stated range.
By their numbers in this assay, from the lowest: compound 4; then compound 3; then compound 1; then compound 2.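

At this aromatic carbon, a hydrogen-bond donor on the attached nitrogen is not required for strong inhibition in this assay: dipropylamino, with none, gives a 9.5-fold lower number from compound 3 to compound 4 (0.98 log units; beyond the scatter) and a 20-fold lower number from compound 1 to compound 4 (1.30 log units; beyond the scatter). The larger of these steps is the change between the two open-chain amines, so an aromatic ring on the nitrogen is not needed either. No evidence on the cause of these steps is available.

The compounds shown do not separate loss of the donor from the change in chains on the nitrogen. Going by these compounds, how a cyclic amine such as piperidine or morpholine would read at this carbon remains open.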